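The source may hold more compounds than are shown below. What is called first, only, known or untested is meant among the compounds shown, and "the series" means these compounds.

Compound 3 `CCOC(=O)CO/N=C/c1c(N)ncnc1Oc1ccc(NC(=O)C2(C(=O)Nc3ccc(F)cc3)CC2)cc1F` stands highest of the three measured compounds in a physicochemical assay for lipophilicity, using the shake flask method; a lower number here means a more polar compound, a higher number a more lipophilic compound: compound 3 gives 3.15. Compound 2 `Nc1ncnc(Oc2ccc(NC(=O)C3(C(=O)Nc4ccc(F)cc4)CC3)cc2F)c1/C=N/O` gives 2.62 in this assay, and compound 1 `N/N=C/c1c(N)ncnc1Oc1ccc(NC(=O)C2(C(=O)Nc3ccc(F)cc3)CC2)cc1F` gives 2.25. The next compound, compound 4 `Nc1ncnc(Oc2ccc(NC(=O)C3(C(=O)Nc4ccc(F)cc4)CC3)cc2F)c1/C=N/OCC(=O)N1CCOCC1`, differs from compound 3 by morpholin-4-yl in place of ethoxy on a carbonyl carbon. Going by the values given here, no measured step covers this exchange on the carbonyl carbon. The nearest guide is a number 0.53 log units higher from compound 2 to compound 3 (beyond the scatter), which shows what the whole (ethoxycarbonyl)methyl arm contributed; a number 0.90 log units higher from compound 1 to compound 3 (beyond the scatter) and a number 0.37 log units higher from compound 1 to compound 2 (beyond the scatter) concern the group on the double-bonded nitrogen as a whole. Since compound 4 keeps the arm but replaces its ethoxy, a downward step of a number 0.70 log units lower from compound 3 to compound 4 (beyond the scatter) is expected. For compound 4 in this assay a value of 2.45 is estimated, within a range of 1.9 to 3.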

Compound 4, partition coefficient: 2.1
Beside the measured number, compound 4's estimate is 0.35 log units above it, within the range that was stated.
By their numbers in this assay, from the lowest: compounds 4 and 1 (each within the scatter of the next); then compound 2; then compound 3.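

In this assay, going by these compounds alone, morpholin-4-yl in place of ethoxy on a carbonyl carbon gives a number 1.05 log units lower from compound 3 to compound 4 (beyond the scatter) and is the first large step, so the far end of the arm carries real weight here. On the oxygen, the ((morpholin-4-yl)carbonyl)methyl arm gives a number 0.52 log units lower from compound 2 to compound 4 (beyond the scatter) and so runs opposite to a number 0.53 log units higher from compound 2 to compound 3 (beyond the scatter) for the ester arm. In place of amino on a double-bonded nitrogen, ((morpholin-4-yl)carbonyl)methoxy gives a number 0.15 log units lower from compound 1 to compound 4 (within the scatter) and so no readable change.

On these data alone, whether dimethylamino in place of morpholin-4-yl, or a free carboxylic acid in place of the ester, would run the same way stays open. No measurement at hand accounts for the size of these steps.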